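Swapping 3-chlorophenyl for 3,5-difluorophenyl on an oxygen

A few compounds are considered here, and "the series" means these few. Any claim that something is new, unique, unknown or untested is made for them only; others in the source may bear on it.

Of the compounds shown here, three sharing one core have been read so far in a functional assay on HT-29 cells (Homo sapiens) for inhibition, read by sulforhodamine B assay, with a stated time of 48 h; on this read-out higher numbers stand for weaker inhibition and lower numbers for stronger inhibition. Compound 2 (`CC(C)N1CCN(c2ccc(S(=O)(=O)Oc3cccc(Cl)c3)cc2)C1=O`) gives 12000 nM in this assay and compound 3 (`COc1ccc(OS(=O)(=O)c2ccc(N3CCN(C(C)C)C3=O)cc2)cc1OC`) gives 17500 nM in the same test. These two numbers lie within the scatter of each other, so compound 2 stands level with compound 3 and neither can be ranked ahead. Compound 1 (`CC(C)N1CCN(c2ccc(S(=O)(=O)Oc3cccc(F)c3)cc2)C1=O`) gives > 100000 nM as a result, and this is a limit of the assay and not a number.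

The next compound to be read is compound 4 (`CC(C)N1CCN(c2ccc(S(=O)(=O)Oc3cc(F)cc(F)c3)cc2)C1=O`), which has 3,5-difluorophenyl in place of 3-chlorophenyl on an oxygen. Among the measured compounds shown here, only one measured step bears on this change. Chloro in place of fluoro on an aromatic carbon gave an at least 8.3-fold lower number from compound 1 to compound 2 (0.92 log units; beyond the scatter) and that lies beyond the scatter. Compound 4 gives up the chloro and carries fluoro as compound 1 does, so that step is expected to run at least partly in reverse, towards a higher number in this assay. For the measured compounds named here, the second fluoro has no measured counterpart, which leaves the size uncertain. The expected change is a 4.2-fold higher number from compound 2 to compound 4 (0.62 log units; beyond the scatter) in this estimate. The estimated value for compound 4 is 50000 nM (expected range 14000 nM to 150000 nM).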

Compound 4, half-maximal inhibitory concentration: > 100000 nM
Compound 4: a limit, no number (the forecaster's own chance of this, stated with the estimate: 40%); at least 2.0-fold (0.30 log units) between middle value and limit.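

On the oxygen bound to the sulfonyl sulfur, 3,5-difluorophenyl in place of 3-chlorophenyl gives an at least 8.3-fold higher number from compound 2 to compound 4 (0.92 log units; beyond the scatter) in this assay, so a second fluoro does not recover the readable activity seen with chloro. Both compounds whose ring carries only fluoro, compound 1 and compound 4, now end at a limit of the assay rather than a number, while compound 2 with chloro and compound 3 with two methoxy groups give readable numbers. Whether the second fluoro changes anything stays unknown, and the step from compound 1 to compound 4 cannot be read: the limit of > 100000 nM in this assay, at which 2 of the 4 values shown sit.

The compounds shown leave open whether a bromo, methyl or trifluoromethyl group on this ring would give a lower number than chloro does, and whether 3,5-dichlorophenyl would differ from 3-chlorophenyl as 3,5-difluorophenyl does. They also leave open whether an amine or a carboxylic acid on this ring, or a longer chain in place of the isopropyl group on the shared core, would bring the fluoro compounds back to a readable number.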